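A few compounds are considered here, and "the series" means these few. Any claim that something is new, unique, unknown or untested is made for them only; others in the source may bear on it.

The measured compounds in a functional assay on HeLa cells (Homo sapiens) for antiproliferative activity, read by MTT assay, with a stated time of 72 h; a higher number here means a weaker inhibitor, a lower number a stronger inhibitor:
compound 1 `O=c1cc(CSC(=S)N2CCCCC2)oc2ccccc12` gives > 25000 nM
compound 2 `O=c1c(Cl)c(CSC(=S)N2CCCCC2)oc2ccccc12` gives 9800 nM

The value of compound 1 is a limit of this assay and not a number (the limit of > 25000 nM in this assay, at which 1 of the 2 values shown sits). Where compound 1 stands is therefore known only as a range, not as a point. Within the data shown here, compound 2 gives a number, and the single measured step, an at least 2.5-fold lower number from compound 1 to compound 2 (0.40 log units; beyond the scatter), shows that one added substituent can move the result beyond the scatter.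

Compound 3 `COc1ccc2oc(CSC(=S)N3CCCCC3)cc(=O)c2c1` differs from compound 1 by methoxy in place of hydrogen on an aromatic carbon. Among the measured compounds shown here, no measured step covers this change: the step from compound 1 to compound 2 concerns a chloro group, not a methoxy group, so it bears on the methoxy change only as a sign that the shared core tolerates a small substituent with a measurable shift. The direction and size for a methoxy group are not given by the data. Compound 3 is expected to sit close to compound 1, with a number no higher from compound 1 to compound 3 (the limit leaves the size open), and a limit rather than a number may again be reported. The estimate for compound 3 is 25000 nM, with a range from 8000 nM to 60000 nM.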

Compound 3, half-maximal inhibitory concentration: 11900 nM
Beside the measured number, compound 3's estimate is 2.1-fold (0.32 log units) above it; the measured number falls inside the stated range.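

In this assay, methoxy in place of hydrogen on an aromatic carbon gives an at least 2.1-fold lower number from compound 1 to compound 3 (0.32 log units; beyond the scatter). This shows that a substituent at this place, on the six-membered aromatic ring of carbon only, can also move the result beyond the scatter. Until now, only the chloro group had done so, with an at least 2.5-fold lower number from compound 1 to compound 2 (0.40 log units; beyond the scatter), and the two substituted compounds now show that such a lower number is not confined to a chloro group or to a single place on the shared core; compound 1 gives > 25000 nM, a limit and not a number, so each step is known only as a minimum, and the full size of the methoxy step stays open: the limit of > 25000 nM in this assay, at which 1 of the 3 values shown sits.

The compounds shown leave open what an amine, a hydroxyl group or a longer alkoxy chain would do on this same aromatic carbon, and whether the methoxy group would give a similar result on another carbon of that ring. They also leave open whether a chloro and a methoxy group together on the shared core would lower the number further than either group alone.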